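A few compounds are considered here, and "the series" means these few. Any claim that something is new, unique, unknown or untested is made for them only; others in the source may bear on it.

Compounds measured so far:
- compound 1 `CCc1nc2c(C)ccnc2n1Cc1ccc(-c2ccccc2C(=O)O)cc1`: 1.26 nM
- compound 2 `Cc1ccnc2c1nc(C(C)C)n2Cc1ccc(-c2ccccc2C(=O)O)cc1`: 31.6 nM

In a functional assay (aorta) with Oryctolagus cuniculus as the target (on this read-out higher numbers stand for weaker binding and lower numbers for tighter binding), compound 2 stands highest of the two numbers, with compound 1 showing a 25-fold higher number from compound 1 to compound 2 (1.40 log units; beyond the scatter). Compound 3 `Cc1ccnc2c1nc(CCCO)n2Cc1ccc(-c2ccccc2C(=O)O)cc1` differs from compound 2 by 3-hydroxypropyl in place of isopropyl on an aromatic carbon. Among the measured compounds shown here, only that single step, from an unbranched chain to a branched one, offers any guidance, and it was large. A return to an unbranched chain may recover part of that loss, so a moderate step toward lower numbers is expected for compound 3, a 4.0-fold lower number from compound 2 to compound 3 (0.60 log units; beyond the scatter). Compound 3 is estimated at 8 nM in this assay, within 2 nM to 60 nM.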

Compound 3, dissociation constant: 501 nM
For compound 3 the middle estimate is 63-fold (1.80 log units) below the measured one, and the stated range ends below it.
By their numbers in this assay, from the lowest: compound 1; then compound 2; then compound 3.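

In this assay, the 3-hydroxypropyl group on this aromatic carbon gives a 16-fold higher number from compound 2 to compound 3 (1.20 log units; beyond the scatter), so an unbranched chain alone does not bring the number back down. Measured against the ethyl chain of compound 1, the added hydroxymethyl gives a 400-fold higher number from compound 1 to compound 3 (2.60 log units; beyond the scatter), a larger rise than the isopropyl group gave in a 25-fold higher number from compound 1 to compound 2 (1.40 log units; beyond the scatter). No measured data on these compounds explain this rise. Still open, as far as these compounds go, is whether the rise follows the chain length or the hydroxyl, a question a plain propyl chain would answer. From the compounds shown here alone, how an amine at the chain end would behave also remains open.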